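This account rests on a few compounds, and the source may have more. Where it says the series, first, only, none or still open, it means among the compounds named here.

Measured compounds:
- compound 1, `CNC(=O)c1cc(Oc2ccc3nc(NC(=O)c4ccc(Cl)cc4)sc3c2)ccn1`, gives 83% in a functional assay on SK-BR-3 cells (Homo sapiens) for inhibition, read by MTT assay, with a stated time of 2 days, tested at 100 uM; a higher number here means more inhibition of growth at the concentration tested, a lower number less inhibition of growth
- compound 2, `CNC(=O)c1cc(Oc2ccc3nc(NC(=O)Nc4ccc(N5CCN(C)CC5)cc4)sc3c2)ccn1`, gives 86.4% in this assay

Compound 2 holds the higher of the two numbers in this assay, but its nearest neighbour, compound 1, sits only a small way lower, and that gap lies within the usual scatter of the measurement. On the numbers shown, the two compounds therefore cannot be told apart.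

Compound 3, `CNC(=O)c1cc(Oc2ccc3nc(NC(=O)Nc4ccc(Cl)cc4)sc3c2)ccn1`, is not yet measured. It differs from compound 2 in one place: chloro in place of 4-methylpiperazin-1-yl on an aromatic carbon, in words chloro in place of 4-methylpiperazin-1-yl on an aromatic carbon. Going by the values given here, no step between two measured compounds isolates this change. Compound 1 carries a chloro group at a corresponding position of its own, and compound 1 gives 83% in this assay, close to compound 2. On that basis the step from compound 2 to compound 3 is expected to be a number 5.4 percentage points lower from compound 2 to compound 3 (within the scatter), no larger than the scatter, in either direction. Compound 3 is estimated to give 81% in this assay, with a range from 62% to 95%.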

Compound 3, percent growth inhibition at one concentration: 77.4%
The estimate for compound 3 lay 3.6 percentage points above the measured number, and the stated range covers the measured number.
By their numbers in this assay, from the lowest: compounds 3, 1 and 2 (each within the scatter of the next).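

Going by these compounds alone, the first direct reading of this position comes from compound 2 and compound 3: in this assay, chloro in place of 4-methylpiperazin-1-yl on an aromatic carbon, para to a large group, gives a number 9 percentage points lower from compound 2 to compound 3 (within the scatter), so a single chlorine atom can stand where the six-membered non-aromatic ring stood without a change beyond the scatter. The link to the 4-chlorophenyl group can now be read as well: (4-chlorophenyl)amino in place of 4-chlorophenyl on a carbonyl carbon gives a number 5.6 percentage points lower from compound 1 to compound 3 (within the scatter), and this step likewise shows no difference that the measurement can resolve. Nothing measured here offers an explanation for either result.

On these data alone, the three compounds therefore remain unseparated at the single concentration tested, and it stays open whether either change would matter at lower concentrations, where growth inhibition is not yet close to its upper end. As far as these compounds go, it also stays open whether a morpholine ring, a carboxylic acid or a longer amine chain on this aromatic carbon would give a step beyond the scatter.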